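The compounds below may be only part of what the source reports. "The series", "measured", "known", "first", "only" and "open" are said of these compounds alone.

Compound 1, `O=C(Oc1ccc2ccc(=O)oc2c1CN1CCc2ccccc2C1)c1ccccc1`: in an ADME assay on MT4 cells (Homo sapiens) for cytotoxicity, read by MTT assay, with a stated time of 96 h (on this read-out higher numbers stand for lower toxicity in this test and lower numbers for higher toxicity in this test), compound 1 reaches only the assay limit, > 100000 nM.
Compound 2, `Cc1cc(=O)oc2c(CN3CCc4ccccc4C3)c(O)ccc12`: in this assay compound 2 likewise reaches only the assay limit, > 100000 nM.
Compound 3, `COc1ccc2c(=O)c(Cc3c(OC(C)=O)ccc4ccc(=O)oc34)c(N3CCCC3)oc2c1`: in this assay compound 3 also reaches only the assay limit, > 100000 nM.

Compound 3 therefore stands nowhere in particular on the numbers shown: its value is a limit, not a measured number, and all three compounds sit at the same ceiling of this assay, (the limit of > 100000 nM in this assay, at which 3 of the 3 values shown sit). No difference among them can be read from this.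

Compound 4, `CCN(CC)c1oc2cc(OC)ccc2c(=O)c1Cc1c(OC(C)=O)ccc2ccc(=O)oc12`, is not yet measured. It differs from compound 3 in one place: diethylamino in place of pyrrolidin-1-yl on an aromatic carbon. Among the compounds with values here, no measured pair shows what such a change does in this assay. Within the data shown here, with every value so far resting at the limit, no step beyond the usual scatter is expected from compound 3 to compound 4 in either direction.

Compound 4 is therefore estimated to show 150000 nM in this assay, within a range from 60000 nM to 400000 nM. This estimate means a step that the limit leaves unreadable from compound 3 to compound 4, and it is expected that the assay again reports only a limit rather than a number.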

Compound 4, half-maximal cytotoxic concentration: 83000 nM
Compound 4: the middle estimate sits 1.8-fold (0.26 log units) above what was measured, and the stated range covers the measured number.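

In this assay, within the data shown here, compound 4 gives 83000 nM, the first value in this set that is a real number rather than a limit. Placing diethylamino instead of pyrrolidin-1-yl on the aromatic carbon next to the ring oxygen gives an at least 1.2-fold lower number from compound 3 to compound 4 (0.08 log units; that floor lies within the scatter), so only a floor for the step is known, and it does not show a real separation between the two compounds. The true size of the step cannot be read because compound 3 rests at a limit: the limit of > 100000 nM in this assay, at which 3 of the 4 values shown sit.

From the compounds shown here alone, what dimethylamino or piperidin-1-yl does at this position remains open, as does whether an open chain reliably gives a lower number than a ring. A single pair cannot show whether the same change behaves alike on a different core.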